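Aryl-piperazine amides: methoxy on the phenyl ring

The source may hold more compounds than are shown below. What is called first, only, known or untested is meant among the compounds shown, and "the series" means these compounds.

Measured so far:
compound 1 `COc1cccc(N2CCN(C(=O)c3oc(C)nc3-c3cccc(F)c3)CC2)c1` — "not active" (no number reported)
compound 2 `Cc1nc(-c2ccccc2)c(C(=O)N2CCN(c3cccc(C)c3C)CC2)o1` — 35 nM
compound 3 `Cc1nc(-c2ccccc2)c(C(=O)N2CCN(c3ccccc3)CC2)o1` — 39.1 nM

Compound 3 gives 39.1 nM in a functional assay on HL-60 cells (Homo sapiens) for inhibition, read by MTT assay, with a stated time of 72 h (on this read-out higher numbers stand for weaker inhibition and lower numbers for stronger inhibition), and stands highest of the two numbers in hand; its nearest neighbour, compound 2, gives 35 nM, and the step of a 1.1-fold higher number from compound 2 to compound 3 (0.05 log units; within the scatter) lies within the scatter. That step, phenyl in place of 2,3-dimethylphenyl on the amine nitrogen in the ring, is the only one bearing on the present change and shows that this ring tolerates a substituent without a shift beyond the scatter. Within the data shown here, compound 1 differs from the new compound in a fluorine on the other ring and is recorded as "not active" (no number reported), with no number; no step to it is worked out, so it only flags that a methoxy-bearing analogue has come out inactive.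

Compound 4 `COc1cccc(N2CCN(C(=O)c3oc(C)nc3-c3ccccc3)CC2)c1` differs from compound 3 by methoxy in place of hydrogen on an aromatic carbon. Given the flat step from compound 2 to compound 3, the expected step of a 1.5-fold higher number from compound 3 to compound 4 (0.19 log units; within the scatter) is small, with the range widened toward weaker inhibition on account of compound 1. Compound 4 is estimated at 60 nM, between 25 nM and 400 nM.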

Compound 4, half-maximal inhibitory concentration: 34.8 nM
Compound 4: middle estimate off by 1.7-fold (0.24 log units), on the high side; the measured number falls inside the stated range.
By their numbers in this assay, from the lowest: compounds 4, 2 and 3 (each within the scatter of the next).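

In this assay, methoxy in place of hydrogen on an aromatic carbon, meta to a large group, gives a 1.1-fold lower number from compound 3 to compound 4 (0.05 log units; within the scatter) and so adds no shift beyond the scatter at this position. The change from 2,3-dimethylphenyl to 3-methoxyphenyl on the amine nitrogen gives a 1.0-fold lower number from compound 2 to compound 4 (0.00 log units; within the scatter) and is equally flat, which places the unsubstituted phenyl and both substituted rings of compounds 2, 3 and 4 within the scatter of one another. The methoxy group alone therefore does not go with a missing number: compound 4 gives 34.8 nM in this series, while compound 1, with a fluorine on the other ring, is recorded as "not active" (no number reported) and its difference from compound 4 cannot be read as a step. No measurement in hand gives a reason for these results.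

As far as these compounds go, whether an amine or a carboxylic acid in place of methoxy on this ring would stay within the same narrow range remains open. Also open, from the compounds shown here alone, is whether the fluorine on the other ring would give the same outcome with the unsubstituted phenyl of compound 3 on the amine nitrogen.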